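The source may hold more compounds than are shown below. What is called first, only, known or untested is meant among the compounds shown, and "the series" means these compounds.

Working notes on the series, read in a functional assay on the whole organism for antagonist activity, with Mus musculus as the target; a higher number here means that more compound is needed for the effect, a lower number that less compound is needed. Compound 1 `CCCCCCCN1CCC(C(=O)Nc2cc(Cl)c(N)cc2OC)CC1` gives > 10 mg/kg, which is a limit of this assay and not a number. Compound 3 `COc1cc(N)c(Cl)cc1NC(=O)C1CCN(CC2CCCCCC2)CC1` likewise gives > 10 mg/kg, again a limit. For the measured compounds named here, compound 2 `CCOc1ccc(CN2CCC(C(=O)Nc3cc(Cl)c(N)cc3OC)CC2)cc1` gives 6.3 mg/kg, the one measured number in the set; the limit of > 10 mg/kg in this assay, at which 2 of the 3 values shown sit, is where the other two sit. Compound 4 `COc1cc(N)c(Cl)cc1NC(=O)C1CCN(Cc2ccc(C)c(C)c2)CC1` is the unmeasured member. Going by the values given here, the steps that bear on it are an at least 1.5-fold lower number from compound 1 to compound 2 (0.20 log units; that floor lies within the scatter), where an aryl group enters, while a step that the two limits leave unreadable from compound 1 to compound 3 and an at least 1.5-fold higher number from compound 2 to compound 3 (0.20 log units; that floor lies within the scatter) leave the cycloheptyl compound at the limit. Compound 4 differs from compound 1 thus: 3,4-dimethylphenyl in place of hexyl on a saturated chain carbon bound to an amine nitrogen in a ring. With an aryl group entering once more, for compound 4 a step of the kind seen in an at least 1.5-fold lower number from compound 1 to compound 2 (0.20 log units; that floor lies within the scatter) is expected, namely an at least 2.0-fold lower number from compound 1 to compound 4 (0.30 log units; that floor lies within the scatter). Compound 4 is accordingly estimated at 5 mg/kg, range 2 mg/kg to 15 mg/kg.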

Compound 4, dose for half-maximal effect: > 8 mg/kg
Compound 4 ended at the assay's limit; the forecaster's own chance of this, stated with the estimate: 35%; middle value at least 1.6-fold (0.20 log units) from the limit.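

In this assay compound 4 stays at a limit and not a number, so this second aryl group on the saturated chain carbon gives no readable value: the limit of > 8 mg/kg in this assay, at which 1 of the 4 values shown sits.

Compound 2 alone holds a number, and an at least 1.2-fold higher number from compound 2 to compound 4 (0.10 log units; that floor lies within the scatter) leaves 3,4-dimethylphenyl and 4-ethoxyphenyl unseparated. The steps to compound 4 from the other two compounds cannot be read, since both ends are limits.

Still open, going by these compounds, is whether the ethoxy group matters for the number of compound 2. Unsubstituted phenyl or 4-methoxyphenyl on this carbon would bear on that.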